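The compounds below may be only part of what the source reports. "The series", "measured", "known", "first", "only" and "open" are said of these compounds alone.

Compound 1 `Nc1ncnc2c1ncn2[C@@H]1O[C@H](CN(CC[C@H](N)C(=O)O)CC2CCC2)[C@@H](O)[C@H]1O`: 32%
Compound 2 `Nc1ncnc2c1ncn2[C@@H]1O[C@H](CN(CC[C@H](N)C(=O)O)CC2CCCC2)[C@@H](O)[C@H]1O`: 24.5%
Compound 3 `C=CCN(CC[C@H](N)C(=O)O)C[C@H]1O[C@@H](n2cnc3c(N)ncnc32)[C@H](O)[C@@H]1O`: 53.9%

Of the compounds shown here, three that share one core have been tested in an assay for inhibition of tRNA (cytosine(38)-C(5))-methyltransferase (Homo sapiens), with a stated time of 5 min, tested at 100 uM; a lower number here means less inhibition, a higher number more inhibition at the concentration tested (going by the name of the read-out). Compound 3 gives the highest of the three numbers. The step of a number 21.9 percentage points higher from compound 1 to compound 3 (beyond the scatter) and the step of a number 29.4 percentage points higher from compound 2 to compound 3 (beyond the scatter) both lie beyond the scatter, whereas the step of a number 7.5 percentage points lower from compound 1 to compound 2 (within the scatter) lies within it. Both ring-bearing compounds thus sit clearly under the vinyl-bearing compound 3.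

Compound 4 `Nc1ncnc2c1ncn2[C@@H]1O[C@H](CN(CC[C@H](N)C(=O)O)Cc2ccccc2)[C@@H](O)[C@H]1O` has not yet been measured. It differs from compound 3 in one place: phenyl in place of vinyl on a saturated chain carbon bound to an amine nitrogen. The two steps that bear on this change are those in which vinyl replaces cyclobutyl or cyclopentyl, each of them a modest rise beyond the scatter. Going the other way, from vinyl to a ring group, a modest fall beyond the scatter is therefore expected. Compound 4 is expected to give 30%, with a range from 10% to 50%. This estimate means an expected step of a number 23.9 percentage points lower from compound 3 to compound 4 (beyond the scatter), downward and beyond the scatter.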

Compound 4, a percentage reported as inhibition, at one concentration (the size of the read-out at that concentration, not a potency): 56.8%
For compound 4 the middle estimate is 26.8 percentage points below the measured one; measured number above the stated range.
By their numbers in this assay, from the lowest: compounds 2 and 1 (each within the scatter of the next); then compounds 3 and 4 (each within the scatter of the next).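

In this assay, phenyl on this saturated chain carbon bound to an amine nitrogen gives a number 2.9 percentage points higher from compound 3 to compound 4 (within the scatter), so a ring at this place does not by itself set a compound under the vinyl-bearing one, as compounds 1 and 2 alone had suggested. The kind of ring matters among these compounds: replacing the saturated rings with phenyl gives a number 32.3 percentage points higher from compound 2 to compound 4 (beyond the scatter) and a number 24.8 percentage points higher from compound 1 to compound 4 (beyond the scatter). Nothing available explains this separation between phenyl and the saturated rings.

The compounds shown leave open whether a phenyl ring carrying a carboxylic acid or an amine, or a longer chain between the nitrogen and the phenyl ring, would keep the number level with compounds 3 and 4. Because each number comes from one concentration, they also leave open how compounds 3 and 4 compare in potency.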